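The source may report more compounds than this note shows. Statements on the series, on what has been measured and on what is new or still open speak of the compounds shown alone.

Measured so far:
compound 1 `O=c1[nH]/c(=N\OCCCCc2ccccc2)ccn1[C@@H]1O[C@H](COP(=O)(O)OP(=O)(O)OP(=O)(O)O)[C@@H](O)[C@H]1O` — 54 nM
compound 2 `O=c1[nH]/c(=N\OCCCc2cccc([N+](=O)[O-])c2)ccn1[C@@H]1O[C@H](COP(=O)(O)OP(=O)(O)OP(=O)(O)O)[C@@H](O)[C@H]1O` — 95 nM

In a functional assay on 1321-N1 cells for agonist activity at P2Y purinoceptor 4 (Homo sapiens), read by scintillation counting and inositol phosphate accumulation (on this read-out lower numbers stand for an effect already at smaller amounts and higher numbers for an effect only at larger amounts of compound), compound 1 gives 54 nM, the lowest of the two numbers recorded. Compound 2 gives 95 nM. Among the compounds with values here, the only step between measured compounds is a 1.8-fold higher number from compound 1 to compound 2 (0.25 log units; within the scatter), and it lies within the scatter, so the two values cannot be ordered.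

Compound 3 `COc1ccc(CCCO/N=c2/ccn([C@@H]3O[C@H](COP(=O)(O)OP(=O)(O)OP(=O)(O)O)[C@@H](O)[C@H]3O)c(=O)[nH]2)cc1` has not been measured in this assay. It differs from compound 1 by 4-methoxyphenyl in place of benzyl on a saturated chain carbon, three bonds along the chain from an oxygen. Within the data shown here, the one measured step that bears on this exchange is a 1.8-fold higher number from compound 1 to compound 2 (0.25 log units; within the scatter), which also swaps the aromatic group on the same saturated chain carbon, three bonds along the chain from an oxygen, and stays within the scatter. On that basis no step beyond the scatter is expected for compound 3, in either direction, though a single comparison gives little footing and a modest shift either way would not surprise.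

The value of compound 3 in this assay is estimated at 65 nM, with a range of 30 nM to 140 nM. This estimate corresponds to an expected step of a 1.2-fold higher number from compound 1 to compound 3 (0.08 log units; within the scatter).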

Compound 3, half-maximal effective concentration: 23 nM
Beside the measured number, compound 3's estimate is 2.8-fold (0.45 log units) above it, outside the stated range (below it).
By their numbers in this assay, from the lowest: compound 3; then compounds 1 and 2 (each within the scatter of the next).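

In this assay, the place on a saturated chain carbon, three bonds along the chain from an oxygen, now proves responsive to the group it carries: 4-methoxyphenyl in place of benzyl gives a 2.3-fold lower number from compound 1 to compound 3 (0.37 log units; beyond the scatter), and 4-methoxyphenyl in place of 3-nitrophenyl gives a 4.1-fold lower number from compound 2 to compound 3 (0.62 log units; beyond the scatter). Both steps are modest but beyond the scatter, so compound 3 stands apart from compound 1 and compound 2, which could not be separated from each other, and the second step shows a difference between two aryl groups carried on the same propyl chain. No measurement offered here accounts for the lower number of compound 3.

The exchange from compound 1 also reads as 4-phenylbutyl to 3-(4-methoxyphenyl)propyl, so the compounds shown do not separate the contribution of the methoxy group from that of the chain; a plain 3-phenylpropyl group would divide the two. Going by these compounds, whether the oxygen of the methoxy group matters also stays open, and 4-methylphenyl and 4-hydroxyphenyl on the same chain would address that.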